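The source may report more compounds than this note shows. Statements on the series, on what has been measured and on what is new or still open speak of the compounds shown alone.

Series notes. Within the data shown here, in an assay on CHO cells for displacement of a labelled ligand from D(4) dopamine receptor (Homo sapiens), read by radioligand binding (a lower number here means a stronger inhibitor, a higher number a weaker inhibitor), three compounds carry numbers so far. Compound 1 `COc1ccccc1N1CCN(CCCNC(=O)NN(Cc2ccccc2)c2ccc(Cl)cc2Cl)CC1` gives 15 nM. Compound 2 `O=C(NCCCN1CCN(c2ccc(Cl)cc2)CC1)NN(Cc1ccccc1)c1ccccc1` gives 9.7 nM. Compound 3 `O=C(NCCCN1CCN(c2ccc(Cl)cc2)CC1)NN(Cc1ccc(F)cc1)c1ccccc1` gives 17 nM. Compound 2 holds the lowest of the three numbers, yet both others stand within the scatter of it, so no order among the three is claimed. Among the measured compounds shown here, the only measured step that changes one place at a time is a 1.8-fold higher number from compound 2 to compound 3 (0.24 log units; within the scatter), a change that stays within the scatter.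

Compound 4 `O=C(NCCCN1CCN(c2ccc(I)cc2)CC1)NN(Cc1ccccc1)c1ccccc1` is the next step out from compound 2: iodo in place of chloro on an aromatic carbon. For the measured compounds named here, no measured pair in this assay swaps one halogen for another on the ring carried by the piperazine; the only halogen step available is a 1.8-fold higher number from compound 2 to compound 3 (0.24 log units; within the scatter), which concerns the benzyl ring and stays within the scatter. Compound 1 differs from compound 2 in more than one place and does not isolate this change. The data therefore give no ground for a step beyond the scatter in either direction. Compound 4 is expected to show a 1.1-fold higher number from compound 2 to compound 4 (0.05 log units; within the scatter) in this assay. The estimate for compound 4 in this assay is 11 nM, with a range from 4 nM to 30 nM.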

Compound 4, inhibition constant: 21 nM
Compound 4: middle estimate off by 1.9-fold (0.28 log units), on the low side, within the range that was stated.
By their numbers in this assay, from the lowest: compounds 2, 1, 3 and 4 (each within the scatter of the next, the first and the last beyond it).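

Among these compounds, at the 4-chlorophenyl of compound 2, iodo in place of chloro gives a 2.2-fold higher number from compound 2 to compound 4 (0.34 log units; beyond the scatter) in this assay, the one measured halogen swap on the ring carried by the piperazine and the one step that passes the scatter, though only modestly. The halogen step on the benzyl ring, a 1.8-fold higher number from compound 2 to compound 3 (0.24 log units; within the scatter), stays within the scatter, so the shown single-place changes now include one that can be told from repeat noise, and it lies at the aromatic carbon para to a large group. With compound 4 at 21 nM, this site still carries iodo with a nanomolar constant, but nothing measured here bears on what lies behind the shift.

Going by these compounds, this rests on a single pair, so whether the value follows the halogen at this place stays open; a bromo or a fluoro on the same ring, or a hydrogen in place of the chloro, would fill in that line. Also open, on these data alone, is whether the same swap gives a similar step on a core with a longer chain between the piperazine and the rest of the molecule.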